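The source may hold more compounds than are shown below. What is called first, only, known or untested is meant among the compounds shown, and "the series" means these compounds.

Measured so far in a physicochemical assay for solubility, read by spectrophotometry, in phosphate buffer, measured as kinetic solubility, with a stated time of 18 h, at pH 7.4; on this read-out lower numbers stand for lower solubility and higher numbers for higher solubility
- compound 1 `O=C(Nc1ccc(F)c(-c2nc3ccccc3o2)c1)c1cc([N+](=O)[O-])ccc1Cl` gives 270 nM
- compound 2 `COc1ccc(-c2nc3ccccc3o2)cc1NC(=O)c1cc([N+](=O)[O-])ccc1Cl` gives 90 nM
- compound 3 `O=C(Nc1cccc(-c2nc3ccccc3o2)c1)c1cc([N+](=O)[O-])ccc1Cl` gives 470 nM

Compound 3 with 470 nM stands level with compound 1 within the scatter and clearly above compound 2. Compound 4 `Cc1ccc(-c2nc3ccccc3o2)cc1NC(=O)c1cc([N+](=O)[O-])ccc1Cl` differs from compound 3 by methyl in place of hydrogen on an aromatic carbon. Compound 2 carries a methoxy on that same carbon, and the step on removing it is clear (a 5.2-fold higher number from compound 2 to compound 3 (0.72 log units; beyond the scatter)). The fluoro of compound 1 sits elsewhere, and its step (a 1.7-fold higher number from compound 1 to compound 3 (0.24 log units; within the scatter)) stays within the scatter, so it offers little guidance. For the measured compounds named here, no measured compound carries this methyl, so a step in the same direction as the methoxy precedent, but probably smaller, is expected (a 2.8-fold lower number from compound 3 to compound 4 (0.44 log units; beyond the scatter)). In this assay the estimate for compound 4 is 170 nM (expected range 60 nM to 450 nM).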

Compound 4, solubility: 310 nM
Compound 4: middle estimate off by 1.8-fold (0.26 log units), on the low side, and the stated range covers the measured number.
By their numbers in this assay, from the lowest: compound 2; then compounds 1, 4 and 3 (each within the scatter of the next).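

In this assay, the ring carbon ortho to a large group and para to a 1,3-benzoxazol-2-yl group carries a methyl with a step inside the scatter (a 1.5-fold lower number from compound 3 to compound 4 (0.18 log units; within the scatter)), so a group here need not cost what methoxy costs. Methyl in place of methoxy on that carbon gives a clear step (a 3.4-fold higher number from compound 2 to compound 4 (0.54 log units; beyond the scatter)), which sets compound 2 apart from compound 3 and compound 4. Nothing measured here explains either step.

With only hydrogen, methyl and methoxy shown on this carbon, it remains open whether the low number is particular to methoxy. An amine, a hydroxyl or a longer chain such as ethyl could fall on either side.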